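This account rests on a few compounds, and the source may have more. Where it says the series, first, only, none or still open, it means among the compounds named here.

Compound 1 `COc1cc(-c2nnc3n2NC(c2ccco2)C(C(=O)c2ccc(Br)cc2)S3)cc(OC)c1OC` gives 42100 nM in a functional assay on A549 cells (Homo sapiens) for cytotoxicity, read by MTT assay, with a stated time of 48 h; a higher number here means a weaker inhibitor, a lower number a stronger inhibitor. Compound 2 `COc1cc(-c2nnc3n2NC(c2ccco2)C(C(=O)C2CC2)S3)cc(OC)c1OC` returns only a limit in this assay, > 100000 nM. Compound 3 `COc1ccc(C(=O)C2Sc3nnc(-c4cc(OC)c(OC)c(OC)c4)n3NC2c2ccco2)cc1` likewise returns only a limit in this assay, > 100000 nM. On the numbers shown, compound 3 therefore stands at the limit of > 100000 nM in this assay, at which 2 of the 3 values shown sit, so its true potency is not pinned down. Compound 4 `COc1cc(-c2nnc3n2NC(c2ccco2)C(C(=O)c2ccc([N+](=O)[O-])cc2)S3)cc(OC)c1OC` differs from compound 3 by nitro in place of methoxy on an aromatic carbon. Going by the values given here, the one measured step on that aromatic carbon is an at least 2.3-fold higher number from compound 1 to compound 3 (0.37 log units; beyond the scatter), whereas a step that the two limits leave unreadable from compound 2 to compound 3 cannot be read. Among the compounds with values here, no measured step sets a nitro against a methoxy, so the direction is open. Since compound 3 sits at a limit, the step of an at least 1.6-fold lower number from compound 3 to compound 4 (0.22 log units; that floor lies within the scatter) is expected to be modest at most. Compound 4 is estimated at 60000 nM, between 25000 nM and 150000 nM.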

Compound 4, half-maximal inhibitory concentration: > 100000 nM
Compound 4: a limit, no number (the forecaster's own chance of this, stated with the estimate: 45%); middle value at least 1.6-fold (0.22 log units) away from the limit.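

With nitro in place of bromo on this aromatic carbon, this assay shows an at least 2.3-fold higher number from compound 1 to compound 4 (0.37 log units; beyond the scatter), the second replacement of bromo there to give such a step, after methoxy. Compound 4 returns only a limit, > 100000 nM. The steps among compound 2, compound 3 and compound 4 cannot be read, and compound 1 alone keeps a number: the limit of > 100000 nM in this assay, at which 3 of the 4 values shown sit.

Going by these compounds, how far compound 3 and compound 4 truly lie apart stays open. So does whether chloro or an amine on this carbon would return a number, as bromo does.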